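The source may report more compounds than this note shows. Statements on the series, on what has been measured and on what is new or still open speak of the compounds shown alone.

Compound 3 `COC(=O)CCNC1=CS(=O)(=O)O[C@@]12[C@@H](CO[Si](C)(C)C(C)(C)C)O[C@@H](n1cc(C)c(=O)n(C)c1=O)[C@@H]2O[Si](C)(C)C(C)(C)C` is one of three analogues built on a shared core that differ in the substituent on an amine nitrogen. In a functional assay on HEL cells (Homo sapiens) for cytotoxicity, read by microscopy (on this read-out lower numbers stand for higher toxicity in this test and higher numbers for lower toxicity in this test), compound 3 reaches only a limit of the assay, >= 400000 nM. Compound 1 `Cc1cn([C@@H]2O[C@H](CO[Si](C)(C)C(C)(C)C)[C@@]3(OS(=O)(=O)C=C3NCCC(=O)OCc3ccccc3)[C@H]2O[Si](C)(C)C(C)(C)C)c(=O)n(C)c1=O` likewise stands at a limit, >= 400000 nM. Compound 2 `CCOC(=O)CNC(=O)NC1=CS(=O)(=O)O[C@@]12[C@@H](CO[Si](C)(C)C(C)(C)C)O[C@@H](n1cc(C)c(=O)n(C)c1=O)[C@@H]2O[Si](C)(C)C(C)(C)C` gives a number, 16000 nM. The step of an at least 25-fold higher number from compound 2 to compound 3 (1.39 log units; beyond the scatter) is large, whereas the step that the two limits leave unreadable from compound 1 to compound 3 cannot be read; the limit of >= 400000 nM in this assay, at which 2 of the 3 values shown sit, is where compound 3 stands. Compound 4 `Cc1cn([C@@H]2O[C@H](CO[Si](C)(C)C(C)(C)C)[C@@]3(OS(=O)(=O)C=C3NCC(=O)O)[C@H]2O[Si](C)(C)C(C)(C)C)c(=O)n(C)c1=O` has not been measured and differs from compound 3 in this way: carboxy in place of (methoxycarbonyl)methyl on a saturated chain carbon bound to an amine nitrogen. For the measured compounds named here, no measured step replaces a (methoxycarbonyl)methyl group with a carboxy group, so none bears directly on this change. Since compound 3 already sits at a limit, the step of a number no higher from compound 3 to compound 4 (the limit leaves the size open) is expected to be none beyond the scatter. Compound 4 is estimated at 400000 nM, between 100000 nM and 400000 nM.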

Compound 4, minimum cytotoxic concentration: 300000 nM
Compound 4: the middle estimate sits 1.3-fold (0.12 log units) above what was measured; measured number inside the range.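

In this assay, carboxy on the saturated chain carbon bound to an amine nitrogen gives a readable number, but the steps, an at least 1.3-fold lower number from compound 3 to compound 4 (0.12 log units; that floor lies within the scatter) and an at least 1.3-fold lower number from compound 1 to compound 4 (0.12 log units; that floor lies within the scatter), show no change beyond the scatter. Against the ((ethoxycarbonyl)methyl)carbamoyl group of compound 2, carboxymethyl gives a 19-fold higher number from compound 2 to compound 4 (1.27 log units; beyond the scatter), so carboxy does not reproduce the lower number of compound 2. Two compounds remain at the top of the range: the limit of >= 400000 nM in this assay, at which 2 of the 4 values shown sit.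

Going by these compounds, whether a primary amide in place of carboxy would lower the number stays open. So does whether the carbamoyl link alone, without the ethyl ester, accounts for the number of compound 2.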